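The source may hold more compounds than are shown below. What is called first, only, known or untested is meant among the compounds shown, and "the series" means these compounds.

This account concerns four amides that share the same pattern of a hydroxylated aromatic acid joined to an aniline. Compound 1, `N#Cc1cccc(NC(=O)c2cc(F)ccc2O)c1`, and compound 3, `O=C(Nc1cccc(C(F)(F)F)c1)c1cc(F)ccc1O`, are built on one core; compound 2, `N#Cc1ccc(NC(=O)c2ccc3cccnc3c2O)cc1`, and compound 4, `O=C(Nc1ccc(C(F)(F)F)cc1)c1ccc2cccnc2c1O`, are built on another. How the core of compound 2 differs from the core of compound 1 is not broken down here.

In a functional assay on KG-1 cells (Homo sapiens) for cytotoxicity, read by luminescence and CellTiter-Glo, with a stated time of 3 days (on this read-out higher numbers stand for weaker inhibition and lower numbers for stronger inhibition), compound 1 gives 9100 nM. Compound 3 gives 1010 nM, and the step between them, a 9.0-fold lower number from compound 1 to compound 3 (0.95 log units; beyond the scatter), comes from a single change, (trifluoromethyl in place of cyano on an aromatic carbon). Compound 2 gives 2320 nM in this assay, a number that sits between those of compound 1 and compound 3.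

Compound 4 has not yet been measured in this assay. It differs from compound 2 by trifluoromethyl in place of cyano on an aromatic carbon. Among the compounds with values here, this is the same kind of change as the one from compound 1 to compound 3, though the surroundings are not identical: in compound 3 the new group sits meta to a large group, while in compound 4 it sits para to a large group. The change occurs twice among these compounds, and only once with a measured outcome.

Resting on the step recorded from compound 1 to compound 3, a 9.0-fold lower number from compound 1 to compound 3 (0.95 log units; beyond the scatter), the step from compound 2 to compound 4 in this assay is expected to be a 5.2-fold lower number from compound 2 to compound 4 (0.71 log units; beyond the scatter), somewhat smaller, since the placement and the core both differ from the measured pair. Compound 4 is therefore estimated at 450 nM in this assay, with a plausible range from 150 nM to 1500 nM.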

Compound 4, half-maximal inhibitory concentration: 3510 nM
For compound 4 the middle estimate is 7.8-fold (0.89 log units) below the measured one; the measured number lies above the stated range.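

In this assay, trifluoromethyl in place of cyano, on an aromatic carbon para to a large group, gives a 1.5-fold higher number from compound 2 to compound 4 (0.18 log units; within the scatter), so on this core the exchange leaves no difference that stands out from the scatter. Set beside the earlier step, the same exchange does not give the same outcome on the two cores: the same change on two cores in this assay, a 9.0-fold lower number (0.95 log units; beyond the scatter) from compound 1 to compound 3 and a 1.5-fold higher number (0.18 log units; within the scatter) from compound 2 to compound 4, 14-fold (1.13 log units) apart, beyond the scatter of two such steps This shows that the lower number seen with compound 3 cannot simply be carried over to another core in this series, but it does not show whether the core, the placement of the group or both set the outcome, since the two pairs differ in both respects, and two pairs give no general rule.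

The compounds shown leave open how the exchange would behave with the core of compound 1 and the group para to a large group, a pair that would separate the core from the placement. They also leave open what an amine, a carboxylic acid or a single chlorine atom would give at this place on either core.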